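Notes on the step from compound 3 to compound 4

The source may hold more compounds than are shown below. What is called first, only, known or untested is meant among the compounds shown, and "the series" means these compounds.

Three compounds have numbers in a functional assay on Jurkat cells (Homo sapiens) for inhibition, read by MTT assay, with a stated time of 72 h; on this read-out lower numbers stand for stronger inhibition and higher numbers for weaker inhibition. Compound 1 `COc1cc(NC(=O)/C=C/c2cccc(OCc3ccccc3)c2)cc(OC)c1OC` gives 3500 nM. Compound 2 `C=C(Br)C(=O)Nc1cccc(/C=C/C(=O)Nc2ccccc2)c1` gives 5000 nM. Compound 3 `C=C(Br)C(=O)Nc1cccc(/C=C/C(=O)Nc2cccc(F)c2)c1` gives 1000 nM, the lowest of the three: compound 1 sits nearest and compound 2 furthest, both gaps beyond the scatter. Among the measured compounds shown here, the one single-point step measured so far, a 5.0-fold lower number from compound 2 to compound 3 (0.70 log units; beyond the scatter), is fluoro in place of hydrogen on an aromatic carbon and moved the read-out beyond the scatter.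

Compound 4 `C=C(Br)C(=O)Nc1cccc(/C=C/C(=O)Nc2ccc(Cl)cc2)c1` differs from compound 3 by 4-chlorophenyl in place of 3-fluorophenyl on an amide-type nitrogen. For the measured compounds named here, no measured step exchanges one halogen-bearing phenyl for another, so the step from compound 2 to compound 3 bears only loosely: it shows that putting a halogen on the phenyl on the amide-type nitrogen shifted the number, not what exchanging 3-fluorophenyl for 4-chlorophenyl does. The expected step of a 1.5-fold higher number from compound 3 to compound 4 (0.18 log units; within the scatter) is therefore small and of uncertain direction, with a wide range. Compound 4 is estimated at 1500 nM in this assay, between 500 nM and 5000 nM.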

Compound 4, half-maximal inhibitory concentration: 2600 nM
The estimate for compound 4 lay 1.7-fold (0.24 log units) below the measured number; low and high end bracket the measured number.
By their numbers in this assay, from the lowest: compound 3; then compounds 4, 1 and 2 (each within the scatter of the next).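

In this assay the swap of 3-fluorophenyl for 4-chlorophenyl on the amide-type nitrogen gives a 2.6-fold higher number from compound 3 to compound 4 (0.41 log units; beyond the scatter) and so shows that one halogen-bearing phenyl cannot simply stand in for another at this position. A halogen alone does not secure a shift beyond the scatter: a 5.0-fold lower number from compound 2 to compound 3 (0.70 log units; beyond the scatter) lies beyond it for fluoro in place of hydrogen, whereas a 1.9-fold lower number from compound 2 to compound 4 (0.28 log units; within the scatter) lies within it for chloro in place of hydrogen. The swap changes the halogen and its place on the ring together, and no supporting data at hand account for the difference.

The compounds shown leave open whether the halogen itself or its place on the ring carries the step from compound 3 to compound 4. Also open, from the compounds shown here alone, is how an amine or a carboxylic acid on this phenyl would compare with either halogen.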